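The compounds below may be only part of what the source reports. "The series", "measured", "known", "first", "only" and "open" are said of these compounds alone.

Of the compounds shown here, three have been measured. Compound 1 `Nc1scc(CN2CCN(c3ccc([N+](=O)[O-])cc3)CC2)c1C(=O)c1ccc(Cl)cc1` gives 1% in an assay on CHO cells for displacement of a labelled ligand from adenosine receptor A1 (Homo sapiens), read by scintillation counting, with a stated time of 120 min, tested at 10 uM; on this read-out higher numbers stand for more inhibition at the one concentration tested (going by the name of the read-out) and lower numbers for less inhibition. Compound 2 `Nc1scc(CN2CCN(c3ccccc3F)CC2)c1C(=O)c1ccc(Cl)cc1` gives 4% in this assay, and compound 3 `Nc1scc(CN2CCN(c3ccccc3Cl)CC2)c1C(=O)c1ccc(Cl)cc1` gives 2% in this assay. Compound 1 holds the lowest of the three numbers, but the step of a number 1 percentage points higher from compound 1 to compound 3 (within the scatter) and the step of a number 3 percentage points higher from compound 1 to compound 2 (within the scatter) are both within the scatter, as is the step of a number 2 percentage points lower from compound 2 to compound 3 (within the scatter), so no order among the three can be read from these numbers; all three stand at the low end of the read-out.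

Compound 4 `Nc1scc(CN2CCN(c3cc(Cl)ccc3Cl)CC2)c1C(=O)c1ccc(Cl)cc1` is not yet measured. Its change from compound 1 is 2,5-dichlorophenyl in place of 4-nitrophenyl on an amine nitrogen in a ring. Going by the values given here, two measured steps bear on it: the step of a number 3 percentage points higher from compound 1 to compound 2 (within the scatter) and the step of a number 1 percentage points higher from compound 1 to compound 3 (within the scatter), each of which also swaps the 4-nitrophenyl on the ring amine nitrogen for a halogen-bearing phenyl, and neither moves the number beyond the scatter. Among the compounds with values here, a second chloro on the entering phenyl has no precedent here. On that basis no step beyond the scatter is expected for compound 4 in this assay, and the estimated step is a number 2 percentage points higher from compound 1 to compound 4 (within the scatter). Compound 4 is therefore expected to give about 3% in this assay, with a range from -6% to 12%.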

Compound 4, a percentage reported as inhibition, at one concentration (the size of the read-out at that concentration, not a potency): 0%
Compound 4: the middle estimate sits 3 percentage points above what was measured; the measured number falls inside the stated range.
By their numbers in this assay, from the lowest: compounds 4, 1, 3 and 2 (each within the scatter of the next).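

Adding a chloro on an aromatic carbon of the phenyl is a change the earlier compounds did not cover, and in this assay it gives no step beyond the scatter: a number 2 percentage points lower from compound 3 to compound 4 (within the scatter). The 2,5-dichlorophenyl group also stays within the scatter of both other phenyl groups tested against it, with a number 1 percentage points lower from compound 1 to compound 4 (within the scatter) and a number 4 percentage points lower from compound 2 to compound 4 (within the scatter), so the amine nitrogen in the ring now carries 4-nitrophenyl, 2-fluorophenyl, 2-chlorophenyl and 2,5-dichlorophenyl with no step beyond the scatter between any of them and all four numbers at the low end of the read-out. No measurement is at hand that explains why the numbers at this position stay so low.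

From the compounds shown here alone, it remains open whether a benzyl group, a pyridine ring or a longer alkyl chain on that nitrogen, in place of a substituted phenyl, would move the number beyond the scatter. Going by these compounds, all four compounds share one core and the same chlorophenyl carbonyl group, so what an amine or a carboxylic acid elsewhere on the core would do also stays open.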